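The source may hold more compounds than are shown below. What is called first, only, known or untested is meant among the compounds shown, and "the series" means these compounds.

Measured compounds in a toxicity assay on HT-29 cells (Homo sapiens) for cytotoxicity; on this read-out higher numbers stand for lower toxicity in this test and lower numbers for higher toxicity in this test:

Compound 1 `CCCn1nc(C(=O)N[C@H]2COc3ccccc3N(C)C2=S)nc1Cc1ccccc1`: compound 1 gives > 100000 nM, a limit of the assay.
Compound 2 `CCCCCn1nc(C(=O)N[C@H]2COc3ccccc3N(C)C2=S)nc1Cc1ccccc1`: compound 2 gives > 100000 nM, also a limit.
Compound 3 `CN1C(=S)[C@@H](NC(=O)c2nc(Cc3ccccc3)n(CCCF)n2)COc2ccccc21`: compound 3 gives > 100000 nM, again a limit.

Compound 3 stands at the limit of > 100000 nM in this assay, at which 3 of the 3 values shown sit. Compound 1 and compound 2 stand at that same limit, so no number separates any pair.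

Compound 4 `CN1C(=S)[C@@H](NC(=O)c2nc(Cc3ccccc3)n(CCCCC#N)n2)COc2ccccc21` differs from compound 3 in one place: cyanomethyl in place of fluoro on a saturated chain carbon, three bonds along the chain from an aromatic nitrogen.

The measured steps at this chain position, a step that the two limits leave unreadable from compound 1 to compound 2, a step that the two limits leave unreadable from compound 1 to compound 3 and a step that the two limits leave unreadable from compound 2 to compound 3, are unreadable in size, both ends of each sitting at the limit of > 100000 nM in this assay, at which 3 of the 3 values shown sit. They give no direction and no magnitude to carry over. Compound 4 is therefore expected to show no step beyond the scatter, a number no higher from compound 3 to compound 4 (the limit leaves the size open), and most likely only a limit again. The estimate for compound 4 in this assay is 100000 nM, with a range of 50000 nM to 300000 nM.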

Compound 4, half-maximal cytotoxic concentration: > 100000 nM
Compound 4 ended at the assay's limit; the forecaster's own chance of this, stated with the estimate: 85%; the middle value sits exactly at the limit.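

No new step can be read between compound 4 and compound 1, compound 2 or compound 3 in this assay, since all four sit at one limit: the limit of > 100000 nM in this assay, at which 4 of the 4 values shown sit.

The compounds shown leave open whether any of these chains gives a value inside the range of this assay.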